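The source may report more compounds than this note shows. Statements on the series, on what has been measured and on what is new or still open speak of the compounds shown alone.

Measured compounds:
Compound 1, `CNS(=O)(=O)NC[C@@H]1CCCc2cc(S(=O)(=O)c3cccc(F)c3)ccc21` — 1 nM
Compound 2, `CN(C)S(=O)(=O)NC[C@@H]1CCCc2cc(S(=O)(=O)c3cccc(F)c3)ccc21` — 2 nM
Compound 3, `CS(=O)(=O)NC[C@@H]1CCCc2cc(S(=O)(=O)c3cccc(F)c3)ccc21` — 0.2 nM

All three were tested in an assay on isolated protein for displacement of a labelled ligand from 5-hydroxytryptamine receptor 6 (Homo sapiens); a lower number here means a stronger inhibitor, a higher number a weaker inhibitor. Compound 3 gives the lowest number of the three: the step of a 5.0-fold lower number from compound 1 to compound 3 (0.70 log units; beyond the scatter) and the step of a 10-fold lower number from compound 2 to compound 3 (1.00 log units; beyond the scatter) both lie beyond the scatter, so compound 3 is the strongest binder among them.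

Compound 4, `CN(C[C@@H]1CCCc2cc(S(=O)(=O)c3cccc(F)c3)ccc21)S(C)(=O)=O`, has not been measured. It differs from compound 3 by methyl in place of hydrogen on a sulfonamide nitrogen. The same change has been made once before, between compound 1 and compound 2: methyl in place of hydrogen on a sulfonamide nitrogen. There it produced a 2.0-fold higher number from compound 1 to compound 2 (0.30 log units; within the scatter), a step that lies within the scatter. The two cores on which this change is made differ by methyl in place of methylamino on a sulfonyl sulfur, a change that itself shifted binding only modestly, as shown above.

Among the compounds with values here, since the one earlier example of this change left binding essentially unchanged, compound 4 is expected to stay close to compound 3, with an estimated step of a 2.0-fold higher number from compound 3 to compound 4 (0.30 log units; within the scatter) resting on a 2.0-fold higher number from compound 1 to compound 2 (0.30 log units; within the scatter). The estimate for compound 4 in this assay is 0.4 nM, expected to fall between 0.15 nM and 1.2 nM.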

Compound 4, inhibition constant: 0.398 nM
Compound 4: middle estimate off by 1.0-fold (0.00 log units), on the high side; low and high end bracket the measured number.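

In this assay the methyl in place of hydrogen on a sulfonamide nitrogen gives a 2.0-fold higher number from compound 3 to compound 4 (0.30 log units; within the scatter) and so behaves alike on the two cores that carry it: the same change on two cores in this assay, a 2.0-fold higher number (0.30 log units; within the scatter) from compound 1 to compound 2 and a 2.0-fold higher number (0.30 log units; within the scatter) from compound 3 to compound 4, 1.0-fold (0.00 log units) apart, within the scatter of two such steps
The larger swaps around this change still register: methyl(methylsulfonyl)amino in place of (dimethylsulfamoyl)amino gives a 5.0-fold lower number from compound 2 to compound 4 (0.70 log units; beyond the scatter) and the same group in place of (methylsulfamoyl)amino gives a 2.5-fold lower number from compound 1 to compound 4 (0.40 log units; beyond the scatter) so the group on the sulfonyl sulfur matters more here than this methyl does. Within the data shown here, two cores are only two examples, and both steps lie within the scatter, so the result supports carrying the change between these two cores but does not show that it would carry to any other core, nor why it is tolerated.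

The compounds shown leave open whether an ethyl group or a longer chain on the same sulfonamide nitrogen would also stay close to compound 3. They also leave open what a cyclopropyl group in place of the methyl on the sulfonyl sulfur would do.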